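Cyclopropyl in place of 4-bromophenyl on compound 2

The source may report more compounds than this note shows. Statements on the series, on what has been measured and on what is new or still open speak of the compounds shown alone.

Of the compounds shown here, three have been measured so far. Compound 1 `O=C1O/C(=C\Cn2cc(-c3ccc(Br)cc3)nn2)C(OCc2ccccc2)=C1OCc1ccccc1` gives > 100000 nM in an ADME assay on HFF cells (Homo sapiens) for cytotoxicity, read by MTT assay, with a stated time of 72 h (on this read-out higher numbers stand for weaker inhibition and lower numbers for stronger inhibition), and this is a limit of the assay, not a number. Compound 3 `O=C1O/C(=C\Cn2cc(-c3cc(C(F)(F)F)cc(C(F)(F)F)c3)nn2)C(OCc2ccccc2)=C1OCc1ccccc1` likewise gives > 100000 nM in this assay and this too is only a limit. Compound 2 `O=C1O[C@H]([C@@H](O)Cn2cc(-c3ccc(Br)cc3)nn2)C(OCc2ccccc2)=C1OCc1ccccc1` gives 5100 nM in this assay and is the only one of the three with a number, so it has no other numerical value to be ranked against.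

Compound 4 `O=C1O[C@H]([C@@H](O)Cn2cc(C3CC3)nn2)C(OCc2ccccc2)=C1OCc1ccccc1` keeps the rest of compound 2 and changes one group: cyclopropyl in place of 4-bromophenyl on an aromatic carbon. Cyclopropyl stands in place of 4-bromophenyl on an aromatic carbon of a five-membered aromatic ring with 3 nitrogen.

For the measured compounds named here, no measured pair shows this change, so the expectation for this assay is a tentative one, with a wide margin: a step toward weaker inhibition, beyond the usual scatter. The estimated step is a 3.5-fold higher number from compound 2 to compound 4 (0.55 log units; beyond the scatter). The assay limit could also be reached here, as the limit of > 100000 nM in this assay, at which 2 of the 3 values shown sit, shows. For compound 4 the expected value is 18000 nM, with an estimated range from 5000 nM to 80000 nM.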

Compound 4, half-maximal inhibitory concentration: 24300 nM
The estimate for compound 4 lay 1.4-fold (0.13 log units) below the measured number, and the stated range covers the measured number.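

For the compounds shown here, until now compound 2 was the only compound with a number in this assay, so this is the first measured step at this position: on an aromatic carbon of the five-membered aromatic ring with 3 nitrogen, cyclopropyl in place of 4-bromophenyl gives a 4.8-fold higher number from compound 2 to compound 4 (0.68 log units; beyond the scatter). The group at this place therefore bears on the read-out, and the step runs toward weaker inhibition, although compound 4 has no six-membered aromatic ring there and only 3 heavy atoms in the group that enters. Compound 4 still gives a number and does not reach the ceiling of the assay, which other compounds in the set do reach: the limit of > 100000 nM in this assay, at which 2 of the 4 values shown sit.

The change removes the bromine and the six-membered aromatic ring together, so this single pair cannot say which of the two carries the step. The compounds shown also leave open how the read-out would respond at this position to an unsubstituted phenyl, a longer alkyl chain or an amine.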